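Trimethoxyphenyl series: meta substituent on the pendant phenyl

The source may report more compounds than this note shows. Statements on the series, on what has been measured and on what is new or still open speak of the compounds shown alone.

Measured so far:
compound 1 `COc1cc(-n2cnc3ccc(-c4cccc(C)c4C)cc32)cc(OC)c1OC` gives 9250 nM
compound 2 `COc1cc(-n2cnc3ccc(-c4cccc([N+](=O)[O-])c4)cc32)cc(OC)c1OC` gives 5410 nM
compound 3 `COc1cc(-n2cnc3ccc(-c4cccc(O)c4)cc32)cc(OC)c1OC` gives 250 nM

All three share one core and differ only in the group on the pendant phenyl. In a functional assay on A549 cells (Homo sapiens) for antiproliferative activity, read by MTT assay, with a stated time of 72 h (on this read-out higher numbers stand for weaker inhibition and lower numbers for stronger inhibition), compound 3 stands lowest of the three numbers: the nearest is compound 2, a 22-fold lower number from compound 2 to compound 3 (1.34 log units; beyond the scatter), and the furthest is compound 1, a 37-fold lower number from compound 1 to compound 3 (1.57 log units; beyond the scatter). Compound 1 and compound 2 lie within the scatter of each other, a 1.7-fold lower number from compound 1 to compound 2 (0.23 log units; within the scatter).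

Compound 4 `COc1cc(-n2cnc3ccc(-c4cccc(Cl)c4)cc32)cc(OC)c1OC` is not yet measured. It differs from compound 3 by chloro in place of hydroxy on an aromatic carbon. Going by the values given here, no measured step covers hydroxy against chloro directly. The two steps that bear on it are those ending in compound 3, a 22-fold lower number from compound 2 to compound 3 (1.34 log units; beyond the scatter) and a 37-fold lower number from compound 1 to compound 3 (1.57 log units; beyond the scatter), both large and both ending in the hydroxy compound; moving away from hydroxy in either measured case gave a much higher number. On that basis compound 4 is expected to give a higher number than compound 3, though the size is uncertain because the step of a 1.7-fold lower number from compound 1 to compound 2 (0.23 log units; within the scatter) shows that two non-hydroxy groups sat close together. The expected step is a 10-fold higher number from compound 3 to compound 4 (1.00 log units; beyond the scatter). Compound 4 is estimated at 2500 nM, with a range from 600 nM to 8000 nM.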

Compound 4, half-maximal inhibitory concentration: 7050 nM
Compound 4: middle estimate off by 2.8-fold (0.45 log units), on the low side; the measured number falls inside the stated range.
By their numbers in this assay, from the lowest: compound 3; then compounds 2, 4 and 1 (each within the scatter of the next).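

Hydroxy and chloro now stand in a direct comparison at this place on the pendant phenyl (in this assay, a 28-fold higher number from compound 3 to compound 4 (1.45 log units; beyond the scatter)), and chloro counts 0 hydrogen-bond donors and 0 acceptors against 1 of each for hydroxy, although that count alone explains nothing. Compound 4 also joins the two other compounds without hydroxy, with no separation beyond the scatter (the steps read a 1.3-fold higher number from compound 2 to compound 4 (0.11 log units; within the scatter) and a 1.3-fold lower number from compound 1 to compound 4 (0.12 log units; within the scatter)), so among these four compounds the low number belongs to compound 3 alone, while 3-chlorophenyl, 3-nitrophenyl and 2,3-dimethylphenyl cannot be told apart. Nothing on hand accounts for the gap between hydroxy and the other groups, or shows how the hydroxy group produces it.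

As far as these compounds go, it remains open whether the low number requires hydroxy itself or can also be reached with an amine, a hydroxymethyl or a carboxylic acid at the same place. A methoxy group there would show whether the hydrogen of the hydroxy matters, and the three non-hydroxy compounds cannot settle that question.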